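A few compounds are considered here, and "the series" means these few. Any claim that something is new, unique, unknown or untested is made for them only; others in the source may bear on it.

In a functional assay on MCF7 cells (Homo sapiens) for cytotoxicity, read by MTT assay, with a stated time of 24 h (on this read-out lower numbers stand for stronger inhibition and higher numbers for weaker inhibition), compound 1 `COc1ccccc1N1CCN(CC(=O)N2CCN(c3nnc(-c4ccccc4)c(-c4ccccc4)n3)CC2)CC1` gives 167000 nM. Compound 2 `O=C(CN1CCN(c2ccccc2Cl)CC1)N1CCN(c2nnc(-c3ccccc3)c(-c3ccccc3)n2)CC1` gives 263000 nM in this assay. The change from compound 1 to compound 2 is chloro in place of methoxy on an aromatic carbon, and it makes a step of a 1.6-fold higher number from compound 1 to compound 2 (0.20 log units; within the scatter). Compound 3 `COc1ccc(-c2nnc(N3CCN(C(=O)CN4CCN(c5cccc(OC)c5)CC4)CC3)nc2-c2ccc(OC)cc2)cc1` returns only a limit in this assay, > 821000 nM, which is the limit of > 821000 nM in this assay, at which 1 of the 3 values shown sits. The difference between the core of compound 3 and the core of compound 1 is not broken down here. Compound 4 `COc1ccc(-c2nnc(N3CCN(C(=O)CN4CCN(c5cccc(Cl)c5)CC4)CC3)nc2-c2ccc(OC)cc2)cc1` has not been measured; it differs from compound 3 by chloro in place of methoxy on an aromatic carbon, the same kind of change as that made from compound 1 to compound 2, though the place here is meta to a large group rather than ortho to a large group. Resting on a 1.6-fold higher number from compound 1 to compound 2 (0.20 log units; within the scatter), the expected step is a step that the limit leaves unreadable from compound 3 to compound 4. Compound 4 is estimated at 1000000 nM, between 500000 nM and 3000000 nM, with a limit the likely report.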

Compound 4, half-maximal inhibitory concentration: > 814000 nM
Compound 4 gave a limit, no number; the forecaster's own chance of this, stated with the estimate: 70%; the middle value does not contradict the limit.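

In this assay compound 3 returns only a limit, > 821000 nM. Compound 4 also returns only a limit, > 814000 nM, so no step can be read between these two compounds. On these data alone, what chloro in place of methoxy does on the core of compound 3 stays open.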